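The source may report more compounds than this note shows. Statements on the series, on what has been measured and on what is new or still open speak of the compounds shown alone.

Measured so far:
compound 1 `CC(C)=CCC1Cc2c(OCCCNS(=O)(=O)c3ccc(C(F)(F)F)cc3)cc(=O)n(CCCO)c2CC1(C)C`: 29.6%
compound 2 `CC(C)=CCC1Cc2c(OCCCNS(=O)(=O)c3ccc(Br)cc3)cc(=O)n(CCCO)c2CC1(C)C`: 19.5%

Within the data shown here, in a functional assay on PANC-1 cells (Homo sapiens) for inhibition, read by MTT assay, with a stated time of 24 h, tested at 10 uM (a higher number here means more inhibition at the concentration tested (going by the name of the read-out), a lower number less inhibition), compound 2 stands lowest of the two numbers; the only measured step, a number 10.1 percentage points lower from compound 1 to compound 2 (beyond the scatter), separates it from compound 1 and lies beyond the scatter, though modest in size.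

Compound 3 `CC(C)=CCC1Cc2c(OCCCOc3ccc([N+](=O)[O-])cc3)cc(=O)n(CCCO)c2CC1(C)C` is not yet measured. Its change from compound 2 is 4-nitrophenoxy in place of ((4-bromophenyl)sulfonyl)amino on a saturated chain carbon, three bonds along the chain from an oxygen on an aromatic ring. Among the measured compounds shown here, the one measured step bears on it only loosely: that step swaps a single substituent on the aromatic ring, whereas here the whole ((4-bromophenyl)sulfonyl)amino group gives way to 4-nitrophenoxy, with a hydrogen-bond donor lost and an acceptor gained. For the measured compounds named here, no measured pair covers such a swap, so direction cannot be read from the data; the size of the measured step suggests that changes move the read-out only modestly. A step of a number 2.5 percentage points higher from compound 2 to compound 3 (within the scatter) in this assay is therefore expected, within the scatter. Compound 3 is estimated at 22%, with a range from 5% to 40%.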

Compound 3, a percentage reported as inhibition, at one concentration (the size of the read-out at that concentration, not a potency): 47.5%
The estimate for compound 3 lay 25.5 percentage points below the measured number, and the stated range ends below it.
By their numbers in this assay, from the lowest: compound 2; then compound 1; then compound 3.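

In this assay, the end of the chain proves far more responsive than the ring substituent alone suggested: 4-nitrophenoxy in place of ((4-bromophenyl)sulfonyl)amino gives a number 28 percentage points higher from compound 2 to compound 3 (beyond the scatter) and so exceeds the earlier change of ring substituent, a number 10.1 percentage points lower from compound 1 to compound 2 (beyond the scatter). The read-out at this position therefore does not depend on keeping the ((4-bromophenyl)sulfonyl)amino group, and activity persists with a group that has no hydrogen-bond donors. No measurement in hand explains the rise.

The step changes the link to the ring and the ring substituent together, so the compounds shown leave open which of these carries the difference. A 4-bromophenoxy group on the same chain would separate the two, and a longer chain would test how far the ring can sit from the core.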